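Aryl swap at the exocyclic alkene carbon, toward compound 4

A few compounds are considered here, and "the series" means these few. Any claim that something is new, unique, unknown or untested is made for them only; others in the source may bear on it.

Compound 3 `O=C1N=C(N2CCC[C@H]2C(=O)Nc2ccc3ncnc(Nc4cccc(Cl)c4)c3c2)S/C1=C/c1ccccc1Br` stands at the weak end of the numbers shown: in a functional assay on A549 cells (Homo sapiens) for antiproliferative activity, read by MTT assay (on this read-out lower numbers stand for stronger inhibition and higher numbers for weaker inhibition), compound 3 gives only a limit, > 50000 nM, and it is the single value sitting at the limit of > 50000 nM in this assay, at which 1 of the 3 values shown sits. Compound 1 `O=C1N=C(N2CCC[C@H]2C(=O)Nc2ccc3ncnc(Nc4cccc(Cl)c4)c3c2)S/C1=C/c1ccccc1F` gives 34500 nM in this assay, and compound 2 `O=C1N=C(N2CCC[C@H]2C(=O)Nc2ccc3ncnc(Nc4cccc(Cl)c4)c3c2)S/C1=C/c1cccc(Br)n1` gives 3100 nM. Among the measured steps, an at least 1.4-fold higher number from compound 1 to compound 3 (0.16 log units; that floor lies within the scatter), whereas an at least 16-fold higher number from compound 2 to compound 3 (1.20 log units; beyond the scatter) and an 11-fold lower number from compound 1 to compound 2 (1.05 log units; beyond the scatter).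

Compound 4 `COc1ccc(/C=C2/SC(N3CCC[C@H]3C(=O)Nc3ccc4ncnc(Nc5cccc(Cl)c5)c4c3)=NC2=O)cc1` differs from compound 3 by 4-methoxyphenyl in place of 2-bromophenyl on a double-bonded chain carbon bound to a double-bonded ring carbon. The measured steps that bear on this change are the two that also exchange the whole group on that carbon, an at least 16-fold higher number from compound 2 to compound 3 (1.20 log units; beyond the scatter) and an 11-fold lower number from compound 1 to compound 2 (1.05 log units; beyond the scatter); both are large, so a step beyond the scatter in this assay is plausible, and the two-carbon-ring-only replacements so far have both landed weak. Going by the values given here, no measured compound carries a 4-methoxyphenyl, so the direction rests on the spread of the three values alone. Compound 4 is expected near 20000 nM, within 4000 nM to 60000 nM, an expected step of an at least 2.5-fold lower number from compound 3 to compound 4 (0.39 log units; beyond the scatter) that could still end as a limit.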

Compound 4, half-maximal inhibitory concentration: 31700 nM
Compound 4: the middle estimate sits 1.6-fold (0.20 log units) below what was measured; measured number inside the range.
By their numbers in this assay, from the lowest: compound 2; then compounds 4 and 1 (each within the scatter of the next). At a limit, above all of these: compound 3.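

In this assay, going by these compounds alone, the 4-methoxyphenyl group, the one aryl group here that carries no halogen, does not close the gap to the 6-bromopyridin-2-yl group, with a 10-fold higher number from compound 2 to compound 4 (1.01 log units; beyond the scatter). With a 1.1-fold lower number from compound 1 to compound 4 (0.04 log units; within the scatter) and an at least 1.5-fold lower number from compound 3 to compound 4 (0.19 log units; that floor lies within the scatter), the 4-methoxyphenyl group cannot be separated from the two halophenyl groups, and of the four aryl groups at this position only 6-bromopyridin-2-yl stands apart. Compound 3 remains a limit and not a number: the limit of > 50000 nM in this assay, at which 1 of the 4 values shown sits.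

The compounds shown leave open whether the stronger inhibition of compound 2 follows the ring nitrogen of its pyridine or the bromo on that ring. A plain pyridin-2-yl group, or an amine in place of the bromo, would separate the two.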